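The source may report more compounds than this note shows. Statements on the series, on what has been measured and on what is new or still open speak of the compounds shown alone.

Measured so far:
- compound 1 `CC(C)N1CCN(Cc2csc(N)c2C(=O)c2ccc(Cl)cc2)CC1`: -7.4%
- compound 2 `Nc1scc(CN2CCN(c3cccc(Cl)c3Cl)CC2)c1C(=O)c1ccc(Cl)cc1`: -77%
- compound 3 `Nc1scc(CN2CCN(c3ccc(Cl)cc3F)CC2)c1C(=O)c1ccc(Cl)cc1`: -81%

In a functional assay on CHO cells with adenosine receptor A1 (Homo sapiens) as the target, read by cAMP accumulation and immunoassay, with a stated time of 6 min, tested at 10 uM (on this read-out higher numbers stand for a weaker effect at the one concentration tested and lower numbers for a stronger effect), compound 3 gives -81%. Among the three numbers compound 3 and compound 2 are not separated, since a number 4 percentage points lower from compound 2 to compound 3 (within the scatter). Both stand far from compound 1: a number 73.6 percentage points lower from compound 1 to compound 3 (beyond the scatter) and a number 69.6 percentage points lower from compound 1 to compound 2 (beyond the scatter). Going by the values given here, the two large steps are the same kind of change, an aryl group in place of isopropyl on the ring nitrogen; the one aryl-for-aryl swap, compound 2 to compound 3, stays within the scatter.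

Compound 4 `Nc1scc(CN2CCN(c3ccc([N+](=O)[O-])cc3)CC2)c1C(=O)c1ccc(Cl)cc1` is not yet measured. The change from compound 3 is 4-nitrophenyl in place of 4-chloro-2-fluorophenyl on an amine nitrogen in a ring. Among the compounds with values here, it is again an aryl-for-aryl swap on the same ring nitrogen, so the only step that bears on it directly is a number 4 percentage points lower from compound 2 to compound 3 (within the scatter). Within the data shown here, no measured compound carries a nitro group, and no measured step covers halogen against nitro on this ring, so the range is set wide. For compound 4 the step of a number 13 percentage points higher from compound 3 to compound 4 (beyond the scatter) is expected to stay within the scatter. The estimate for compound 4 is -68%, between -90% and -30%.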

Compound 4, a percentage reported as activity, at one concentration (the size of the read-out at that concentration, not a potency): -17%
Compound 4: the middle estimate sits 51 percentage points below what was measured; measured number outside the range, above it.
By their numbers in this assay, from the lowest: compounds 3 and 2 (each within the scatter of the next); then compounds 4 and 1 (each within the scatter of the next).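

In this assay the aryl group on this ring nitrogen turns out not to be interchangeable: the change to 4-nitrophenyl gives a number 64 percentage points higher from compound 3 to compound 4 (beyond the scatter) and a number 60 percentage points higher from compound 2 to compound 4 (beyond the scatter) in contrast to the earlier aryl-for-aryl swap, which stayed within the scatter. An aryl group in this place therefore does not by itself bring the large step seen with 2,3-dichlorophenyl and 4-chloro-2-fluorophenyl, as there is only a number 9.6 percentage points lower from compound 1 to compound 4 (within the scatter) and 4-nitrophenyl is not separated from isopropyl. Nothing at hand explains why 4-nitrophenyl departs from the two halogen-bearing aryl groups.

The compounds shown leave open whether a phenyl carrying a nitrile or an amine in place of the nitro group would stand with compound 4 or with compound 3. Where an unsubstituted phenyl falls on this read-out is also open.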